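The source may hold more compounds than are shown below. What is called first, only, known or untested is meant among the compounds shown, and "the series" means these compounds.

Measured so far in a functional assay on HCT-116 cells (Homo sapiens) for antiproliferative activity, read by MTT assay, with a stated time of 72 h; a higher number here means a weaker inhibitor, a lower number a stronger inhibitor:
- Compound 1 `Cc1ccc(-c2cn(C/C=C3\OC(=O)C(OCc4ccccc4)=C3OCc3ccccc3)nn2)cc1`: > 100000 nM
- Compound 2 `O=C1O[C@H]([C@@H](O)Cn2cc(-c3cccc(O)c3)nn2)C(OCc2ccccc2)=C1OCc1ccccc1`: 42900 nM

Compound 1 gives a reading that is a limit of the assay, not a number. Among the measured compounds shown here, that leaves compound 2 with the only numeric reading in the set, so it cannot yet be ranked against a second number. Its value of 42900 nM is all that anchors the next comparison.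

The next compound to be tested is compound 3 `O=C1O[C@H]([C@@H](O)Cn2cc(C3CC3)nn2)C(OCc2ccccc2)=C1OCc1ccccc1`. It keeps the core of compound 2 and changes in one place, with cyclopropyl in place of 3-hydroxyphenyl on an aromatic carbon of a five-membered aromatic ring with 3 nitrogen: cyclopropyl in place of 3-hydroxyphenyl on an aromatic carbon.

For the measured compounds named here, no measured pair in this small set shows what such a replacement does in this assay, so the expectation rests on compound 2 at 42900 nM alone. The expected step is a 1.3-fold higher number from compound 2 to compound 3 (0.11 log units; within the scatter), with none beyond the scatter anticipated, although a reading that is only a limit remains possible. For compound 3 the estimated value is 55000 nM, with an expected range of 20000 nM to 100000 nM.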

Compound 3, half-maximal inhibitory concentration: 30400 nM
Beside the measured number, compound 3's estimate is 1.8-fold (0.26 log units) above it; the measured number falls inside the stated range.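

In this assay, among the compounds shown here, the step is a 1.4-fold lower number from compound 2 to compound 3 (0.15 log units; within the scatter), the first step in this set that can be read as a number. On this aromatic carbon of the five-membered aromatic ring with 3 nitrogen, 3-hydroxyphenyl, with its six-membered aromatic ring, hydrogen-bond donor and hydrogen-bond acceptor, can give way to the smaller cyclopropyl, which has no donor or acceptor, and the two readings still stand within the scatter of each other. The reading at this level therefore does not depend on the 3-hydroxyphenyl group, although compound 1 remains the one compound here whose reading is a limit and not a number: the limit of > 100000 nM in this assay, at which 1 of the 3 values shown sits.

Going by these compounds, with only these two groups compared at this position, it stays open whether a plain phenyl, an amine, a carboxylic acid or a longer chain such as n-hexyl on the same carbon would move the number beyond the scatter. On these data alone, compound 1 differs from compound 2 and compound 3 in more than one place, so what its other differences contribute also remains open.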